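Cytotoxicity of benzimidazole analogues on HEp-2 cells

This account rests on a few compounds, and the source may have more. Where it says the series, first, only, none or still open, it means among the compounds named here.

Measured compounds:
compound 1, `CC(C)CCn1c(Cn2c(=O)n(C(C)C)c3ccccc32)nc2cc(C(C)(C)N)ccc21`: 3270 nM
compound 2, `CC(C)CCn1c(Cn2c(=O)n(CC(=O)OC(C)(C)C)c3ccccc32)nc2cc(C(=N)N)ccc21`: 7900 nM
compound 3, `CNCc1ccc2nc(Cn3c(=O)n(C(C)C)c4ccccc43)n(CCC(C)C)c2c1`: 4810 nM

Three compounds sharing one core were tested in an ADME assay on HEp-2 cells (Homo sapiens) for cytotoxicity; a lower number here means that less compound is tolerated, a higher number that more compound is tolerated. Compound 1 gives 3270 nM, compound 2 gives 7900 nM and compound 3 gives 4810 nM in this assay. Among these three numbers, compound 1 stands lowest. Its gap to compound 3 lies within the scatter of the assay, so no order between those two can be read; its gap to compound 2 lies beyond the scatter, so compound 2 is tolerated at a higher concentration than compound 1 in this assay.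

Compound 4, `CC(C)CCn1c(Cn2c(=O)n(C(C)C)c3ccccc32)nc2cc(C(N)=O)ccc21`, has not yet been measured. It differs from compound 1 in one place: carbamoyl in place of 1-amino-1-methylethyl on an aromatic carbon.

Going by the values given here, no step between measured compounds with exactly this change is available, so the expectation rests on the narrow span of the three numbers. Compound 4 is expected to lie close to compound 1, with a step of a 1.7-fold higher number from compound 1 to compound 4 (0.23 log units; within the scatter) that may be no larger than the scatter. Compound 4 is therefore estimated at 5500 nM in this assay, within a range from 2500 nM to 14000 nM.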

Compound 4, half-maximal cytotoxic concentration: 23400 nM
Estimate against measurement, compound 4: 4.3-fold (0.63 log units) below, outside the stated range (above it).
By their numbers in this assay, from the lowest: compounds 1, 3 and 2 (each within the scatter of the next, the first and the last beyond it); then compound 4.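

Placing carbamoyl in place of 1-amino-1-methylethyl on this aromatic carbon gives a 7.2-fold higher number from compound 1 to compound 4 (0.85 log units; beyond the scatter) in this assay and so shows that this position can move the number well beyond the scatter, something the narrow span of the three earlier numbers did not reveal. The two groups have the same computed count of hydrogen-bond donors and acceptors and neither carries a net charge, so those counts do not separate them, even though compound 4 at 23400 nM stands above all three earlier numbers. Nothing available here bears on why this change shifts the number.

The compounds shown leave open whether the higher number goes with the arrival of the carbonyl or with the departure of the amine, a question that a carboxylic acid, a methyl ester or a simple isopropyl group on the same aromatic carbon would help to separate. They also leave open whether the step would hold with a group other than isopropyl on the ring nitrogen of the shared core, such as the tert-butyl ester side chain of compound 2.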